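The source may hold more compounds than are shown below. What is called first, only, known or untested is meant among the compounds shown, and "the series" means these compounds.

Measured so far:
compound 1 `c1cncc(N2C[C@H]3CCNC[C@H]32)c1` — 1540 nM
compound 2 `COc1cc(N2C[C@H]3CCNC[C@H]32)cnc1Br` — 202 nM
compound 3 `N#Cc1cncc(N2C[C@H]3CCNC[C@H]32)c1` — 5560 nM

In a functional assay on HEK293 cells for agonist activity at Neuronal acetylcholine receptor; alpha3/beta4 (Homo sapiens), read by FLIPR (a lower number here means that less compound is needed, a higher number that more compound is needed for the effect), compound 3 stands at the highest number of the three: compound 1 lies a 3.6-fold higher number from compound 1 to compound 3 (0.56 log units; beyond the scatter) step away from it, and compound 2, with its methoxy and bromo groups on the shared core, gives a number far lower than compound 3. For the measured compounds named here, the only step that bears on the change at hand is that from compound 1 to compound 3, a 3.6-fold higher number from compound 1 to compound 3 (0.56 log units; beyond the scatter), where a cyano was introduced on an aromatic carbon.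

Compound 4 `COc1cncc(N2C[C@H]3CCNC[C@H]32)c1` carries methoxy in place of cyano on an aromatic carbon, two atoms from the ring nitrogen. Taking the cyano away would be expected to undo the rise seen in a 3.6-fold higher number from compound 1 to compound 3 (0.56 log units; beyond the scatter), bringing the number back toward that of compound 1; what the methoxy adds on this carbon has not been measured, though compound 2, which also carries a methoxy, gives the lowest number of the set. Compound 4 is therefore expected to show a drop of about a 4.6-fold lower number from compound 3 to compound 4 (0.67 log units; beyond the scatter) in this assay. The estimate for compound 4 is 1200 nM, within a range of 400 nM to 3500 nM.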

Compound 4, half-maximal effective concentration: 4360 nM
The estimate for compound 4 lay 3.6-fold (0.56 log units) below the measured number, outside the stated range (above it).
By their numbers in this assay, from the lowest: compound 2; then compound 1; then compounds 4 and 3 (each within the scatter of the next).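

In this assay, methoxy and cyano on this carbon, two atoms from the ring nitrogen, cannot be told apart, with a 1.3-fold lower number from compound 3 to compound 4 (0.11 log units; within the scatter), and the step from hydrogen to methoxy (a 2.8-fold higher number from compound 1 to compound 4 (0.45 log units; beyond the scatter)) goes the same way as the step from hydrogen to cyano (a 3.6-fold higher number from compound 1 to compound 3 (0.56 log units; beyond the scatter)). Methoxy on this carbon therefore does not by itself bring the low number of compound 2, and the presence of bromo is what separates that compound, with a 22-fold higher number from compound 2 to compound 4 (1.33 log units; beyond the scatter) marking the step when hydrogen takes its place. No measured evidence accounts for these shifts.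

The compounds shown leave open whether bromo would give so low a number without the methoxy. They also leave open how an amine or a longer chain such as ethoxy would compare on the carbon that holds the cyano or methoxy.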